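The source may report more compounds than this note shows. Statements on the series, on what has been measured and on what is new or still open speak of the compounds shown alone.

Measured so far in an ADME assay on HepG2 cells (Homo sapiens) for cytotoxicity, read by MTT assay, with a stated time of 48 h; a higher number here means that more compound is tolerated, a lower number that less compound is tolerated:

Compound 1 `C#CCN(c1nc(-c2cccc(Br)c2)no1)C1CCCCC1`: 53.5 ug/mL
Compound 2 `CC(=O)OC[C@H]1O[C@H](OC[C@@H](Cn2cc(CN(c3nc(-c4ccc(Cl)cc4)no3)C3CCCCC3)nn2)OC(C)=O)C=C[C@@H]1OC(C)=O`: 46.9 ug/mL

Compound 2 carries the acetylated sugar and triazole attached through a methylene to the shared aminoxadiazole core, whereas compound 1 has a propargyl group in that place. In this assay compound 2 gives 46.9 ug/mL, and compound 1 gives 53.5 ug/mL; the two numbers lie within the usual scatter of each other, so nothing separates the two compounds on this read-out.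

Compound 3 `CC(=O)OC[C@H]1O[C@H](OC[C@@H](Cn2cc(CN(c3nc(-c4ccccc4)no3)C3CCCCC3)nn2)OC(C)=O)C=C[C@@H]1OC(C)=O` is the next member to be tested. Its difference from compound 2 is hydrogen in place of chloro on an aromatic carbon, that is, 4-chlorophenyl becomes phenyl on the oxadiazole. Among the compounds with values here, no pair of measured compounds shows this particular change, so there is no measured step to lean on. Since the far larger swap between compound 1 and compound 2 left the half-maximal cytotoxic concentration essentially unchanged, the removal of a single chlorine is expected to move the number little, if at all, beyond the scatter. For compound 3 in this assay the expected value is 50 ug/mL, within a range of 25 ug/mL to 100 ug/mL, which corresponds to an expected step of a 1.1-fold higher number from compound 2 to compound 3 (0.03 log units; within the scatter).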

Compound 3, half-maximal cytotoxic concentration: 19.9 ug/mL
Beside the measured number, compound 3's estimate is 2.5-fold (0.40 log units) above it; measured number outside the range, below it.
By their numbers in this assay, from the lowest: compound 3; then compounds 2 and 1 (each within the scatter of the next).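

In this assay, replacing 4-chlorophenyl with phenyl gives a 2.4-fold lower number from compound 2 to compound 3 (0.37 log units; beyond the scatter), a modest step but one beyond the scatter, so less of compound 3 is tolerated. Compound 1 and compound 2 differ in more than one place and could not isolate this position, whereas this pair shows that a single chloro on this aromatic carbon, para to a large group, is enough on its own to register on this read-out, with the chlorinated compound being the better tolerated of the two. Nothing available here accounts for the step, which is recorded only as a measured difference.

This single pair leaves open whether the shift depends on chloro specifically or would also appear with another group at this place, such as fluoro, methoxy or an amine. It also leaves open whether the same exchange would produce a step of similar size on a compound carrying the propargyl group of compound 1 rather than the acetylated sugar and triazole.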